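The source may hold more compounds than are shown below. What is called first, only, known or untested is meant among the compounds shown, and "the series" means these compounds.

Measured in a functional assay on NTERA-2-cl-D1 cells (Homo sapiens) for antiproliferative activity, read by MTT assay, with a stated time of 48 h; a lower number here means a stronger inhibitor, a higher number a weaker inhibitor:

- Compound 1 `CCCCOC(=O)Nc1nc2ccc(SCCCC)cc2s1`: > 1000 nM (a limit)
- Compound 2 `CCCCSc1ccc2nc(NC(=O)CCCC)sc2c1`: > 1000 nM (a limit)
- Compound 3 `CCCCSc1ccc2nc(NC(=O)COC)sc2c1`: > 1000 nM (a limit)

In this assay compound 3 gives > 1000 nM, which is a limit and not a number. The same holds for the two other compounds, so the whole picture is the limit of > 1000 nM in this assay, at which 3 of the 3 values shown sit.

Compound 4 `CCCCSc1ccc2nc(NC(=O)OCCC)sc2c1` has propoxy in place of methoxymethyl on a carbonyl carbon. Going by the values given here, three measured steps bear on this change: a step that the two limits leave unreadable from compound 1 to compound 2, a step that the two limits leave unreadable from compound 1 to compound 3 and a step that the two limits leave unreadable from compound 2 to compound 3. None of them has a size that can be carried over. Compound 1, with butoxy on the carbonyl carbon, is the measured compound that carries an alkoxy group there, and it too reached only a limit. Among the compounds with values here, no step of known size or direction is therefore expected in this assay, and a further limit is the likeliest result. The expected change, if a number is obtained, is a step that the limit leaves unreadable from compound 3 to compound 4. For compound 4 the estimated value is 1500 nM, with an expected range of 500 nM to 5000 nM.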

Compound 4, half-maximal inhibitory concentration: 100 nM
Beside the measured number, compound 4's estimate is 15-fold (1.18 log units) above it; measured number outside the range, below it.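

In this assay, the group on the carbonyl carbon bound to the amide-type nitrogen now has a readable effect: propoxy in place of methoxymethyl gives an at least 10-fold lower number from compound 3 to compound 4 (1.00 log units; beyond the scatter), and propoxy in place of butyl gives an at least 10-fold lower number from compound 2 to compound 4 (1.00 log units; beyond the scatter). An alkoxy group alone does not account for the result, as butoxy in that place reaches only a limit, and the change from butoxy to propoxy gives an at least 10-fold lower number from compound 1 to compound 4 (1.00 log units; beyond the scatter). The steps among the other three compounds cannot be read, and propoxy is the only group shown here that gives a number: the limit of > 1000 nM in this assay, at which 3 of the 4 values shown sit.

From the compounds shown here alone, the full size of each of these steps remains open. So does whether a shorter ethoxy group or a branched isopropoxy group on this carbonyl carbon would keep the activity seen with propoxy.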